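A few compounds are considered here, and "the series" means these few. Any claim that something is new, unique, unknown or untested is made for them only; others in the source may bear on it.

Compound 1, with the structure `COc1ccc(-n2ccnc2-c2cc(OC)c(OC)c(OC)c2)cc1[N+](=O)[O-]`, and compound 2, with the structure `COc1ccc(-n2ccnc2-c2cc(OC)c(OC)c(OC)c2)cc1N`, share one core and differ at a single place, namely (amino in place of nitro on an aromatic carbon). In a functional assay on T47D cells (Homo sapiens) for antiproliferative activity, read by MTT assay, with a stated time of 72 h (a higher number here means a weaker inhibitor, a lower number a stronger inhibitor), compound 1 gives 10000 nM, while compound 2 gives 500 nM; the step between them, a 20-fold lower number from compound 1 to compound 2 (1.30 log units; beyond the scatter), is a large one. Compound 3, with the structure `COc1ccc(C(=O)Nc2cc(OC)c(OC)c(OC)c2)cc1[N+](=O)[O-]`, is built on another core, and the difference between the two cores is not broken down here. In this assay compound 3 gives 6000 nM, a number close to that of compound 1 and well apart from that of compound 2.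

Compound 4, with the structure `COc1ccc(C(=O)Nc2cc(OC)c(OC)c(OC)c2)cc1N`, has not yet been measured. It differs from compound 3 by amino in place of nitro on an aromatic carbon, the same change as that made from compound 1 to compound 2, at a place described in the same words. The step expected for compound 4 is a 10-fold lower number from compound 3 to compound 4 (1.00 log units; beyond the scatter), an expectation resting on the step of a 20-fold lower number from compound 1 to compound 2 (1.30 log units; beyond the scatter), tempered by the different core on which compound 3 stands. On that basis the estimate for compound 4 in this assay is 600 nM, with a range from 200 nM to 2000 nM.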

Compound 4, half-maximal inhibitory concentration: > 100000 nM
Compound 4 ended at the assay's limit (the forecaster's own chance of this, stated with the estimate: 5%); middle value at least 160-fold (2.22 log units) away from the limit.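

In this assay the step on the core of compound 3 is an at least 16-fold higher number from compound 3 to compound 4 (1.22 log units; beyond the scatter), which runs opposite to the step on the core of compound 1, and the two steps do not agree: the same change on two cores in this assay, a 20-fold lower number (1.30 log units; beyond the scatter) from compound 1 to compound 2 and an at least 16-fold higher number (1.22 log units; beyond the scatter) from compound 3 to compound 4, at least 330-fold (2.52 log units) apart, beyond the scatter of two such steps. Compound 4 gives > 100000 nM, which is a limit of the assay and not a number, so only the direction of this step and its smallest possible size are known: the limit of > 100000 nM in this assay, at which 1 of the 4 values shown sits. This shows that, in this series, the effect of amino in place of nitro cannot be carried from one of these cores to the other, but with a single pair on each core it does not show why the two cores part, nor how the change would behave on any further core.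

The compounds shown leave open which part of the difference between the two cores goes with the reversal. Also open, on these data alone, is what other groups at this place, such as a hydroxyl, a methylamino or an acetamido group, would give on each core.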